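The compounds below may be only part of what the source reports. "The series", "measured", "known", "first", "only" and "open" are said of these compounds alone.

Measured so far in a functional assay on the whole organism with Rattus norvegicus as the target; a lower number here means that less compound is needed, a higher number that more compound is needed for the effect:
- Compound 1 `CCN(CC)C(=O)Cn1c(=N)sc2cc(OC(F)(F)F)ccc21`: 9 mg/kg
- Compound 2 `C[S+]([O-])CCCn1c(=N)sc2cc(OC(F)(F)F)ccc21`: 2.3 mg/kg

Compound 2 holds the lower of the two numbers, 2.3 mg/kg, so less of it is needed for the effect than of compound 1. The next compound to be tested, compound 3 `CC[S+]([O-])CCn1c(=N)sc2cc(OC(F)(F)F)ccc21`, has the same atoms as compound 2, joined differently: a group of 4 heavy atoms (2 carbon, 1 oxygen, 1 sulfur; no ring) in place of a group of 4 heavy atoms (2 carbon, 1 oxygen, 1 sulfur; no ring), on a saturated chain carbon, two bonds along the chain from an aromatic nitrogen. The exchange sits on a saturated chain carbon, two bonds along the chain from an aromatic nitrogen.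

Within the data shown here, only one measured step bears on this change: a 3.9-fold lower number from compound 1 to compound 2 (0.59 log units; beyond the scatter). That step is modest but beyond the scatter, and it replaced a group with a smaller one. Here, the group that enters has the same size as the group that leaves, and no measured pair shows a rearrangement of this kind. A smaller step is therefore expected in this assay, with no clear direction and probably none beyond the scatter. The expected step is a 1.3-fold higher number from compound 2 to compound 3 (0.12 log units; within the scatter). For compound 3, the estimate is 3 mg/kg, with an expected range from 1 mg/kg to 9 mg/kg.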

Compound 3, dose for half-maximal effect: 1.2 mg/kg
Beside the measured number, compound 3's estimate is 2.5-fold (0.40 log units) above it, and the stated range covers the measured number.
By their numbers in this assay, from the lowest: compounds 3 and 2 (each within the scatter of the next); then compound 1.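

In this assay, joining the same atoms differently along the chain gives a 1.9-fold lower number from compound 2 to compound 3 (0.28 log units; within the scatter), so this rearrangement has no effect that can be told apart from the usual variation between repeated measurements. Among these compounds, the larger difference remains the one between the amide-bearing group and the sulfur-bearing chains: exchanging the group gives a 7.5-fold lower number from compound 1 to compound 3 (0.88 log units; beyond the scatter), and with the step already seen for compound 2, this makes both sulfur-bearing compounds clearly separate from compound 1 in this assay. Nothing here gives a measured reason for either result.

The three compounds cannot show how far this tolerance extends: a longer chain, a sulfone, a thioether or an amine in the same place might keep the dose low or raise it. All three also carry the same trifluoromethoxy group on the shared core, so its part in the effect, compared with a chlorine or methoxy group, remains an open question.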